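The source may hold more compounds than are shown below. What is called first, only, known or untested is meant among the compounds shown, and "the series" means these compounds.

Measured compounds:
compound 1, `CN(C)C(=O)c1cc2cnc(Nc3ccc(S(=O)(=O)NCCCCCN=C=S)cc3)nc2n1C1CCCC1`, giving 52.1% in a functional assay on NCI-H1299 cells (Homo sapiens) for inhibition, read by CCK-8 assay, with a stated time of 72 h, tested at 1 uM; on this read-out higher numbers stand for a stronger effect at the one concentration tested and lower numbers for a weaker effect
compound 2, `CN(C)C(=O)c1cc2cnc(Nc3ccc(C(=O)NCCCCCN=C=S)cc3)nc2n1C1CCCC1`, giving 50.3% in this assay

Within the data shown here, compound 1 stands highest of the two numbers, yet its only neighbour is compound 2, and the step of a number 1.8 percentage points lower from compound 1 to compound 2 (within the scatter) is within the scatter, so the two compounds cannot be told apart on this assay.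

Compound 3, `CN(C)C(=O)c1cc2cnc(Nc3ccc(C(=O)NCCCCCCN=C=S)cc3)nc2n1C1CCCC1`, has not been measured. It differs from compound 1 in one place: a group of 12 heavy atoms (8 carbon, 2 nitrogen, 1 oxygen, 1 sulfur; no ring) in place of a group of 12 heavy atoms (6 carbon, 2 nitrogen, 2 oxygen, 2 sulfur; no ring), on an aromatic carbon. The change has two parts: the sulfonyl link of compound 1 is replaced by a carbonyl, as in compound 2, and the chain carrying the isothiocyanate is longer by one carbon.

Among the measured compounds shown here, only one measured step bears on this. The step from compound 1 to compound 2 covers the sulfonyl-to-carbonyl exchange and came out at a number 1.8 percentage points lower from compound 1 to compound 2 (within the scatter), within the scatter. Nothing measured covers the longer chain. The expectation for this assay is therefore no step beyond the scatter, with a wider range to allow for the untested extension: the estimated step is a number 2.1 percentage points lower from compound 1 to compound 3 (within the scatter).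

For compound 3 the estimate in this assay is 50%, ranging from 37% to 63%.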

Compound 3, a percentage reported as inhibition, at one concentration (the size of the read-out at that concentration, not a potency): 49.4%
For compound 3 the middle estimate is 0.6 percentage points above the measured one; the measured number falls inside the stated range.
By their numbers in this assay, from the lowest: compounds 3, 2 and 1 (each within the scatter of the next).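

In this assay, the added carbon in the chain carrying the isothiocyanate now has a measured step of its own (a number 0.9 percentage points lower from compound 2 to compound 3 (within the scatter)), so at this position the longer chain cannot be told apart from the shorter one. The full change, which swaps the sulfonyl link for a carbonyl and lengthens the chain, also stays inside the usual scatter (a number 2.7 percentage points lower from compound 1 to compound 3 (within the scatter)), so the two parts together leave all three compounds indistinguishable on this read-out. No other measurement bears on this result, so nothing here explains why the number stays so flat.

Still open, on these data alone, is whether a much longer chain, or a much shorter one, would shift the number beyond the scatter, since the two chain lengths compared here sit only one carbon apart. It is also unclear how much the isothiocyanate itself contributes, which a compound carrying a plain amine or an acrylamide at the end of the same chain could show.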